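The compounds below may be only part of what the source reports. "The series", "measured", "known", "first", "only" and "open" are said of these compounds alone.

Measured compounds:
compound 1, `c1ccc2c(c1)CN[C@@H](CN(CCCCNCC1CCCCC1)[C@H]1CCCc3cccnc31)C2`, 158 nM in a functional assay on cells for antagonist activity at C-X-C chemokine receptor type 4 (Homo sapiens), read by fluorescence and calcium flux, with stated times of 25 min and 90 s; a higher number here means a weaker inhibitor, a lower number a stronger inhibitor
compound 2, `c1ccc2c(c1)CN[C@@H](CN(CCCCNCC1CCNCC1)[C@H]1CCCc3cccnc31)C2`, 36.5 nM in this assay
compound 3, `O=S1(=O)CCC(CNCCCCN(C[C@H]2Cc3ccccc3CN2)[C@H]2CCCc3cccnc32)CC1`, 17 nM in this assay

Compound 3 gives the lowest number of the three in this assay. The step to it from compound 2 is a 2.1-fold lower number from compound 2 to compound 3 (0.33 log units; beyond the scatter), and from compound 1 it is a 9.3-fold lower number from compound 1 to compound 3 (0.97 log units; beyond the scatter), so it stands apart from both by more than the scatter. The compound not yet measured, compound 4, has the structure `O=S1(=O)CCC(NCCCCN(C[C@H]2Cc3ccccc3CN2)[C@H]2CCCc3cccnc32)CC1`. It differs from compound 3 in one place: 1,1-dioxothian-4-yl in place of (1,1-dioxothian-4-yl)methyl on an amine nitrogen. The ring itself is kept; only the saturated carbon that joined it to the amine nitrogen is gone.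

Going by the values given here, none of the measured steps touches this linker. The steps of a 4.3-fold lower number from compound 1 to compound 2 (0.64 log units; beyond the scatter) and a 9.3-fold lower number from compound 1 to compound 3 (0.97 log units; beyond the scatter) exchange the ring on that saturated chain carbon, and a 2.1-fold lower number from compound 2 to compound 3 (0.33 log units; beyond the scatter) does the same, all with the carbon in place. They therefore say nothing direct about shortening the link. Among the compounds with values here, with no comparable precedent, the expected change is a small one, set near the scatter, as a 1.5-fold higher number from compound 3 to compound 4 (0.17 log units; within the scatter). Compound 4 is estimated at 25 nM in this assay, within the range 8 nM to 80 nM.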

Compound 4, half-maximal inhibitory concentration: 45.5 nM
Estimate against measurement, compound 4: 1.8-fold (0.26 log units) below, within the range that was stated.
By their numbers in this assay, from the lowest: compound 3; then compounds 2 and 4 (each within the scatter of the next); then compound 1.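

In this assay, going by these compounds alone, the saturated carbon that joined the ring to the amine nitrogen proves to matter: with the 1,1-dioxothian-4-yl ring kept, taking that carbon away gives a 2.7-fold higher number from compound 3 to compound 4 (0.43 log units; beyond the scatter) and so changes the link alone, where the earlier steps had changed only the ring. The loss leaves compound 4 still ahead of the cyclohexylmethyl compound, with a 3.5-fold lower number from compound 1 to compound 4 (0.54 log units; beyond the scatter) on record, and it cannot be told apart from the (piperidin-4-yl)methyl compound, as a 1.2-fold higher number from compound 2 to compound 4 (0.10 log units; within the scatter) stays within the scatter, so the directly attached sulfone ring gives up the edge that its (1,1-dioxothian-4-yl)methyl counterpart held over compound 2. Nothing in the data shown accounts for this effect of the link.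

The compounds shown leave open whether the same shortening would cost as much with piperidin-4-yl or cyclohexyl set directly on the amine nitrogen, since the effect of the link is seen with one ring only. They also leave open whether a longer chain, such as 2-(1,1-dioxothian-4-yl)ethyl, would lower the number further or raise it again.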